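Methyl on the ring nitrogen: from compound 2 to compound 4

The source may report more compounds than this note shows. Statements on the series, on what has been measured and on what is new or still open speak of the compounds shown alone.

Measured compounds:
- compound 1 `CCCCNc1nc(N)nc2c1CCN(Cc1ccccc1)C2`: 0.4 uM
- compound 2 `CCCCNc1nc(N)nc2c1CCNC2`: 0.6 uM
- compound 3 `CCCCNc1nc(N)nc2c1CN(C)CC2`: 0.03 uM

In an assay on HEK293 cells for agonist activity at Toll-like receptor 8 (Homo sapiens), read by a luciferase reporter, with a stated time of 6 h (on this read-out lower numbers stand for an effect already at smaller amounts and higher numbers for an effect only at larger amounts of compound), compound 2 gives 0.6 uM, the highest of the three numbers. Compound 1 sits nearest to it, and the step of a 1.5-fold higher number from compound 1 to compound 2 (0.18 log units; within the scatter) lies within the scatter. Going by the values given here, compound 3 stands furthest away, its number being well below that of compound 2, but compound 3 differs from compound 2 in more than one place, so no single step connects the two.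

The unmeasured compound 4 `CCCCNc1nc(N)nc2c1CCN(C)C2` differs from compound 2 by a single change: methyl in place of hydrogen on an amine nitrogen in a ring.

Among the compounds with values here, only one measured step touches the same amine nitrogen in a ring, namely the step from compound 1 to compound 2, in which a large group on that nitrogen was exchanged for hydrogen without a change beyond the scatter. A methyl entering at the same place is a smaller change than that one. On that basis the expected step of a 1.7-fold lower number from compound 2 to compound 4 (0.23 log units; within the scatter) is small, possibly toward a lower number, but not clearly beyond the scatter. Compound 4 is therefore estimated at 0.35 uM, within a range from 0.1 uM to 1 uM.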

Compound 4, minimum effective concentration: 0.2 uM
The estimate for compound 4 lay 1.8-fold (0.24 log units) above the measured number, within the range that was stated.
By their numbers in this assay, from the lowest: compound 3; then compounds 4, 1 and 2 (each within the scatter of the next, the first and the last beyond it).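

In this assay, going by these compounds alone, the step, a 3.0-fold lower number from compound 2 to compound 4 (0.48 log units; beyond the scatter), is the first change on this amine nitrogen in a ring that goes beyond the scatter, although it is a modest one. A methyl in place of hydrogen therefore registers at this position, whereas the much larger benzyl group in place of hydrogen did not, as the earlier step, a 1.5-fold higher number from compound 1 to compound 2 (0.18 log units; within the scatter), showed. The third side of this small set, a 2.0-fold lower number from compound 1 to compound 4 (0.30 log units; within the scatter), stays within the scatter, so methyl and benzyl on this nitrogen cannot be told apart, and only hydrogen and methyl are separated.

The compounds shown leave open whether ethyl, a longer chain or an acetyl group on the same nitrogen would stay close to compound 4 or return to the number of compound 2 at 0.6 uM. No measurement shown here speaks to what lies behind the step from hydrogen to methyl.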